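The source may hold more compounds than are shown below. What is called first, only, known or untested is meant among the compounds shown, and "the series" means these compounds.

In an ADME assay on Vero cells (Chlorocebus sabaeus) for cytotoxicity, read by MTT assay, with a stated time of 72 h (a lower number here means that less compound is tolerated, a higher number that more compound is tolerated), the measured compounds stand as follows
- compound 1 `COc1c(N2CCN(CCC#N)C(C)C2)c(F)cc2c(=O)c(C(=O)O)cn(C3CC3)c12` at 500 ug/mL
- compound 2 `CO/N=C(\C)CCN1CCN(c2c(F)cc3c(=O)c(C(=O)O)cn(C4CC4)c3c2OC)CC1C` at 157 ug/mL

Of these two, compound 2 has the lower number (157 ug/mL) and compound 1 has the higher number (500 ug/mL). The gap between them lies beyond the scatter. Compound 3 `COc1c(N2CCN(CC/C(C)=N/NC(N)=O)C(C)C2)c(F)cc2c(=O)c(C(=O)O)cn(C3CC3)c12` differs from compound 2 in one place (ureido in place of methoxy on a double-bonded nitrogen) with ureido in place of methoxy on a double-bonded nitrogen. Within the data shown here, the only measured step that bears on this change is a 3.2-fold lower number from compound 1 to compound 2 (0.50 log units; beyond the scatter) and it shows no more than that replacing a group in this part of the structure can move the number by a modest amount. Among the measured compounds shown here, no measured compound carries ureido, so that single step gives no firm direction. In this assay a step of modest size or smaller is therefore expected, and a slight rise is only a tentative guess. The expected step is a 1.1-fold higher number from compound 2 to compound 3 (0.06 log units; within the scatter) and this estimate stays within the scatter. Compound 3 is estimated at 180 ug/mL (70 ug/mL to 450 ug/mL).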

Compound 3, half-maximal cytotoxic concentration: 31.3 ug/mL
The estimate for compound 3 lay 5.8-fold (0.76 log units) above the measured number; measured number below the stated range.
By their numbers in this assay, from the lowest: compound 3; then compound 2; then compound 1.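

In this assay, ureido in place of methoxy on a double-bonded nitrogen gives a 5.0-fold lower number from compound 2 to compound 3 (0.70 log units; beyond the scatter), which shows that the end group alone can move the number beyond the scatter while the rest of the structure stays the same, something the earlier pair, with its whole side group replaced, could not separate. Measured against the nitrile-bearing compound 1, the change now reaches a 16-fold lower number from compound 1 to compound 3 (1.20 log units; beyond the scatter), and across these three compounds the number falls as the group on the saturated chain carbon grows, with none going against that order. Nothing measured here offers a reason for the fall seen with ureido.

The compounds shown leave open whether the fall follows the hydrogen-bond donors that ureido brings or simply its larger size, a question that hydroxy on the same double-bonded nitrogen, which is smaller than ureido yet carries a donor, could help to settle. They also leave open whether the fall depends on the carbonyl oxygen of ureido, which thioureido, with sulfur in its place, could test.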